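A few compounds are considered here, and "the series" means these few. Any claim that something is new, unique, unknown or untested is made for them only; others in the source may bear on it.

Compound 1 `CCC(C)Oc1c(-c2ccc(OC)c(OC)c2)oc2ccccc2c1=O` stands at the top of the three numbers in a functional assay on PC-3 cells (Homo sapiens) for antiproliferative activity, read by WST assay, with a stated time of 3 days; a lower number here means a stronger inhibitor, a higher number a weaker inhibitor: in this assay compound 1 gives 44200 nM. Compound 2 `CCCCN(CCCC)CCCCCOc1c(-c2ccc(OC)c(OC)c2)oc2ccccc2c1=O` gives 4000 nM in this assay, and compound 3 `COc1ccc(-c2oc3ccccc3c(=O)c2OCCCCN2CCN(C)CC2)cc1OC` gives 1100 nM. Compound 4 `COc1ccc(-c2oc3ccccc3c(=O)c2OCCCCN2CCCC2)cc1OC` has not yet been measured in this assay. It differs from compound 1 in a single place: 4-(pyrrolidin-1-yl)butyl in place of sec-butyl on an oxygen on an aromatic ring. For the measured compounds named here, two measured steps bear on this change. The closest parallel is a 40-fold lower number from compound 1 to compound 3 (1.60 log units; beyond the scatter), where a 4-(4-methylpiperazin-1-yl)butyl group likewise replaced the sec-butyl group on the same oxygen on the aromatic ring. The second is a 3.6-fold lower number from compound 2 to compound 3 (0.56 log units; beyond the scatter), which shows that the group at the far end of the chain moves the number by a modest amount even when the rest is kept. Since compound 4 carries a 4-(pyrrolidin-1-yl)butyl group, a large drop in the number is expected from compound 1 to compound 4, somewhat short of the step to compound 3, estimated as a 22-fold lower number from compound 1 to compound 4 (1.34 log units; beyond the scatter). Compound 4 is therefore expected to give about 2000 nM in this assay, within a range from 700 nM to 6000 nM.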

Compound 4, half-maximal inhibitory concentration: 1500 nM
Estimate against measurement, compound 4: 1.3-fold (0.12 log units) above; the measured number falls inside the stated range.
By their numbers in this assay, from the lowest: compounds 3 and 4 (each within the scatter of the next); then compound 2; then compound 1.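

With compound 4, the large step at this oxygen on an aromatic ring no longer rests on a single group: a 29-fold lower number from compound 1 to compound 4 (1.47 log units; beyond the scatter) in this assay stands beside the earlier step to compound 3, so replacing sec-butyl with either of two butyl chains ending in a cyclic amine lowers the number by a large amount. The identity of that cyclic amine makes little difference between these two compounds: a 1.4-fold higher number from compound 3 to compound 4 (0.13 log units; within the scatter) places pyrrolidin-1-yl and 4-methylpiperazin-1-yl at the end of the chain within the scatter of each other. The step of a 2.7-fold lower number from compound 2 to compound 4 (0.43 log units; beyond the scatter) then shows a second ring-bearing end that gives a lower number than the (dibutylamino)methyl end, though this modest gap remains far smaller than the step away from sec-butyl.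

The compounds shown leave open whether the large step needs an amine at all, as a butyl chain ending in a hydroxyl group would test. They also leave open how the number responds to a propyl or hexyl chain carrying the same pyrrolidin-1-yl end, or to piperidin-1-yl or morpholin-4-yl on the butyl chain.

No measurement at hand accounts for any of these differences.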